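This account rests on a few compounds, and the source may have more. Where it says the series, first, only, none or still open, it means among the compounds named here.

Series notes. For the measured compounds named here, compound 1 `CCCOC(=O)C1=C(C)NC(=O)NC1c1ccco1` is the first entry in an assay on membranes from HeLa cells for displacement of a labelled ligand from adenosine receptor A3 (Homo sapiens), read by scintillation counting, with a stated time of 180 min, tested at 1 uM (a higher number here means more inhibition at the concentration tested (going by the name of the read-out), a lower number less inhibition), where compound 1 gives 3%. Compound 2 `CC1=C(C(=O)OCC2CC2)C(c2ccco2)NC(=O)N1` carries cyclopropyl in place of ethyl on a saturated chain carbon bound to an oxygen next to a carbonyl group; in this assay compound 2 gives 1%. The step of a number 2 percentage points lower from compound 1 to compound 2 (within the scatter) is within the scatter, so the two numbers cannot be told apart; both sit at the bottom of the measured range, and compound 2 stands with compound 1 there, its nearest neighbour.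

Compound 3 `CC1=C(C(=O)OCC2CCC2)C(c2ccco2)NC(=O)N1` is the next step on the same chain carbon: cyclobutyl in place of cyclopropyl on a saturated chain carbon bound to an oxygen next to a carbonyl group. Going by the values given here, the one measured step that bears on this position, a number 2 percentage points lower from compound 1 to compound 2 (within the scatter), changed nothing beyond the scatter, and the two values at hand give no sign that the ring size at this site moves the number. The step of a number 1 percentage points higher from compound 2 to compound 3 (within the scatter) is therefore expected to be none beyond the scatter. For compound 3 the estimate is 2%, expected to fall between -8% and 12%.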

Compound 3, a percentage reported as inhibition, at one concentration (the size of the read-out at that concentration, not a potency): 1%
Compound 3: middle estimate off by 1 percentage points, on the high side; low and high end bracket the measured number.
By their numbers in this assay, from the lowest: compounds 2, 3 and 1 (each within the scatter of the next).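

In this assay a second ring size can now be read on the saturated chain carbon bound to an oxygen next to a carbonyl group: cyclobutyl in place of cyclopropyl gives no change at the digits printed from compound 2 to compound 3 (within the scatter) and so adds nothing the read-out can detect. Against the open chain, cyclobutyl in place of ethyl gives a number 2 percentage points lower from compound 1 to compound 3 (within the scatter) as well, so ethyl, cyclopropyl and cyclobutyl at this place cannot be told apart, and the flat picture now rests on three compounds rather than two. Nothing at hand offers an explanation for this flatness.

For the compounds shown here, all three numbers sit close to nil at a single concentration, so they show only that these small carbon groups leave the read-out unmoved, not that this place is insensitive to change in general. Going by these compounds, whether a larger group such as cyclohexyl or benzyl, or a chain ending in an amine or a carboxylic acid, would raise the number at this place remains open, as does the effect of changes elsewhere on the shared core.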